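Coumarin-Lipoate Conjugates: Toward a Dimethoxyphenyl Analogue

A few compounds are considered here, and "the series" means these few. Any claim that something is new, unique, unknown or untested is made for them only; others in the source may bear on it.

Measured compounds:
compound 1 `CC(=O)c1cc2ccc(OCCCn3cc(CNC(=O)CCCCC4CCSS4)nn3)cc2oc1=O`: 35.5%
compound 2 `O=C(CCCCC1CCSS1)NCc1cn(CCCCOc2ccc3ccc(=O)oc3c2)nn1`: 45.9%
compound 3 `CC(=O)c1cc2ccc(OCCCCCn3cc(CNC(=O)CCCCC4CCSS4)nn3)cc2oc1=O`: 27.4%

In a functional assay on PC-12 cells (Rattus norvegicus) for cytotoxicity, read by MTT assay, with stated times of 3 h and 2 h, tested at 1 uM (on this read-out higher numbers stand for a stronger effect at the one concentration tested and lower numbers for a weaker effect), compound 3 gives the lowest of the three numbers. Its nearest neighbour is compound 1, whose number is higher by an amount within the scatter, so no order between the two can be read; compound 2 stands higher than compound 3 by an amount beyond the scatter.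

Compound 4 `COc1ccc(-c2cc3ccc(OCCCCCn4cc(CNC(=O)CCCCC5CCSS5)nn4)cc3oc2=O)cc1OC` has not been measured. It differs from compound 3 in one place: 3,4-dimethoxyphenyl in place of acetyl on an aromatic carbon

Going by the values given here, no step between measured compounds shows what this change does. The author expects, in this assay, no step beyond the scatter from compound 3 to compound 4, the estimated step being a number 2.6 percentage points higher from compound 3 to compound 4 (within the scatter). Compound 4 is therefore expected to give about 30%, within 15% to 50%.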

Compound 4, a percentage reported as activity, at one concentration (the size of the read-out at that concentration, not a potency): 42.2%
Beside the measured number, compound 4's estimate is 12.2 percentage points below it; low and high end bracket the measured number.
By their numbers in this assay, from the lowest: compounds 3, 1, 4 and 2 (each within the scatter of the next, the first and the last beyond it).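

In this assay, the group on this aromatic carbon, two atoms from the ring oxygen, proves to matter: 3,4-dimethoxyphenyl in place of acetyl gives a number 14.8 percentage points higher from compound 3 to compound 4 (beyond the scatter), a modest step. The position therefore carries a group with more heavy atoms and an added aromatic ring, and the number does not fall. Nothing at hand explains the step.

Whether the added ring or its two methoxy groups account for the step stays open. A plain phenyl or a carboxylic acid on this carbon would bear on that, as would the same exchange on the linker of compound 1.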